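Methoxy to fluoro on one aryl arm of compound 1

A few compounds are considered here, and "the series" means these few. Any claim that something is new, unique, unknown or untested is made for them only; others in the source may bear on it.

Going by the values given here, compound 1 `C=CCn1c(=O)/c(=C\c2ccccc2OC)[nH]c(=O)/c1=C\c1ccccc1OC` is the only member of the series with a number: in a functional assay on MOLT-4 cells (Homo sapiens) for cytotoxicity, read by CCK-8 assay, with a stated time of 72 h (on this read-out lower numbers stand for stronger inhibition and higher numbers for weaker inhibition), compound 1 gives 13100 nM. Compound 2 `COc1ccccc1/C=c1/[nH]c(=O)/c(=C\c2ccccc2OC)[nH]c1=O` has no result in this assay; for compound 2 the entry reads "not determined" (no result reported). Compound 3 `C=CCn1c(=O)/c(=C\c2ccccc2F)[nH]c(=O)/c1=C\c1ccccc1OC` differs from compound 1 by fluoro in place of methoxy on an aromatic carbon. Among the compounds with values here, no measured pair shows this change, so the step is expected to stay small, with a slight drift toward weaker inhibition; the estimated step in this assay is a 1.2-fold higher number from compound 1 to compound 3 (0.09 log units; within the scatter). Compound 3 is therefore expected to give 16000 nM in this assay, within a range from 5000 nM to 50000 nM.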

Compound 3, half-maximal inhibitory concentration: 20000 nM
For compound 3 the middle estimate is 1.3-fold (0.10 log units) below the measured one; the range from low to high includes it.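

In this assay the change from 2-methoxyphenyl to 2-fluorophenyl on one aryl arm gives a 1.5-fold higher number from compound 1 to compound 3 (0.18 log units; within the scatter) and so cannot be told from repeat scatter. Methoxy is therefore not required at this position to hold the activity of compound 1. No measured data bear on why the two groups read alike. Still open, from the compounds shown here alone, is whether an amine or a carboxylic acid here would shift the number beyond the scatter. The same holds for fluoro on the second aryl arm of compound 3.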